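The compounds below may be only part of what the source reports. "The series", "measured", "known", "first", "only" and "open" are said of these compounds alone.

Compound 1 `COc1ccc(N2C[C@@H](C)N[C@@H](C)C2)cc1NS(=O)(=O)c1ccc(-c2cc(Cl)ccc2F)cc1` is the reference point of this pair. In a functional assay for agonist activity at growth hormone secretagogue receptor type 1 (Homo sapiens), read by FLIPR (a higher number here means that more compound is needed for the effect, a lower number that less compound is needed), compound 1 gives 0.501 nM, which is the lowest of the two numbers recorded. For the measured compounds named here, its only measured companion is compound 2 `COc1ccc(N2C[C@@H](C)N[C@@H](C)C2)cc1NS(=O)(=O)c1cccc(-c2ccccc2)c1`, which carries a plain phenyl on a different position of the sulfonyl ring; in this assay compound 2 gives 158 nM, a far higher number that lies well beyond the scatter. Going by the values given here, no direct single-point step between these two compounds is defined, so their two values can only be set side by side.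

Compound 3 `COc1ccc(N2C[C@@H](C)N[C@@H](C)C2)cc1NS(=O)(=O)c1ccc(OCc2ccccc2)cc1` is the unmeasured compound. It differs from compound 1 by a single change: benzyloxy in place of 5-chloro-2-fluorophenyl on an aromatic carbon. Among the compounds with values here, there is no measured pair that isolates this kind of exchange, so the size of the step can only be expected, not read off. A move in this assay is expected toward a higher number, beyond the scatter, a 20-fold higher number from compound 1 to compound 3 (1.30 log units; beyond the scatter). For compound 3 the expected value in this assay is 10 nM, with a range from 1 nM to 100 nM.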

Compound 3, half-maximal effective concentration: 100 nM
Compound 3: the middle estimate sits 10-fold (1.00 log units) below what was measured; the range from low to high includes it.
By their numbers in this assay, from the lowest: compound 1; then compounds 3 and 2 (each within the scatter of the next).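

In this assay, putting benzyloxy in place of 5-chloro-2-fluorophenyl gives a 200-fold higher number from compound 1 to compound 3 (2.30 log units; beyond the scatter), although the two groups have the same heavy-atom count and each holds one six-membered aromatic ring of carbon only. For the compounds shown here, this is the first step that can be read on its own, as the earlier compounds offered none, and it shows that this aromatic carbon, para to a large group, is far from indifferent to what it carries. Matching the heavy-atom count and keeping an aromatic ring of carbon only therefore did not hold the number near that of compound 1 when the chlorine and fluorine left and an oxygen and a hydrogen-bond acceptor entered.

Going by these compounds alone, the single exchange leaves open whether the step follows the oxygen, the added carbon or the lost halogens, a question that groups such as phenoxy, benzyl or 5-chloro-2-fluorobenzyloxy at this same place could help to separate. Nothing available offers an explanation for the size of this step.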